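A few compounds are considered here, and "the series" means these few. Any claim that something is new, unique, unknown or untested is made for them only; others in the source may bear on it.

Working notes. In an assay for inhibition of Polyunsaturated fatty acid 5-lipoxygenase (Homo sapiens), read by spectrophotometry, tested at 20 uM (a higher number here means more inhibition at the concentration tested (going by the name of the read-out), a lower number less inhibition), compound 1 `O=C(/C=C/C=C/c1ccc(Cl)cc1)N1CCCCC1` gives 14.5%, the second highest of three numbers. Compound 2 `COc1ccc(/C=C/C=C/C=C/C(=O)N2CCCCC2)cc1` gives 1.08% in this assay, lower than compound 1 beyond the scatter. Compound 3 `COc1cc(/C=C/C=C/C(=O)N2CCCCC2)cc(OC)c1OC` gives 66.7% in this assay, the highest of the three and well above compound 1. Compound 4 `CSc1ccc(/C=C/C=C/C(=O)N2CCCCC2)cc1` is not yet measured in this assay. It differs from compound 1 in one place: methylsulfanyl in place of chloro on an aromatic carbon. Among the measured compounds shown here, no measured pair differs only at this place, so nothing is known about the size of such a step. The step of a number 9.5 percentage points higher from compound 1 to compound 4 (within the scatter) is expected to be a small rise, possibly not beyond the scatter. For compound 4 an inhibition of 24% is expected, with a range from 5% to 52%.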

Compound 4, a percentage reported as inhibition, at one concentration (the size of the read-out at that concentration, not a potency): 11.8%
The estimate for compound 4 lay 12.2 percentage points above the measured number; the range from low to high includes it.
By their numbers in this assay, from the lowest: compound 2; then compounds 4 and 1 (each within the scatter of the next); then compound 3.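

Methylsulfanyl in place of chloro on an aromatic carbon, para to a large group, gives a number 2.7 percentage points lower from compound 1 to compound 4 (within the scatter) as the first step read at this position. In this assay the two groups therefore cannot be told apart, even though methylsulfanyl brings one more heavy atom and a hydrogen-bond acceptor. No measurement on hand offers an explanation for this result.

As far as these compounds go, whether an amine or a carboxylic acid at this position would give a step beyond the scatter remains open. Also open, from the compounds shown here alone, is whether the same exchange would read alike on a longer chain.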